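Swapping the Aryl Group on a Cyclopentyl Urea

The compounds below may be only part of what the source reports. "The series", "measured", "known", "first", "only" and "open" are said of these compounds alone.

Compound 1 `CC(C)c1cccc(C(C)C)c1NC(=O)NCC1(c2ccc(F)cc2)CCCC1`: 23 nM
Compound 2 `CC(C)c1cccc(C(C)C)c1NC(=O)NCC1(c2ccccc2C(F)(F)F)CCCC1`: 18 nM

Both were tested in an assay on microsomes for inhibition of acyl-CoA:cholesterol acyltransferase (Oryctolagus cuniculus); on this read-out higher numbers stand for weaker inhibition and lower numbers for stronger inhibition. Compound 2 has the lower of the two numbers, but its gap to compound 1 lies within the scatter, so the two cannot be told apart. For the measured compounds named here, the single measured step, a 1.3-fold lower number from compound 1 to compound 2 (0.11 log units; within the scatter), exchanged one aryl group for another on a saturated ring carbon with no real effect. Compound 3 `CC(C)c1cccc(C(C)C)c1NC(=O)NCC1(c2cccc([N+](=O)[O-])c2)CCCC1` brings a third aryl group: 3-nitrophenyl in place of 2-(trifluoromethyl)phenyl on a saturated ring carbon. Because a 1.3-fold lower number from compound 1 to compound 2 (0.11 log units; within the scatter) stayed within the scatter, only a small shift is expected here, a 1.4-fold higher number from compound 2 to compound 3 (0.14 log units; within the scatter). The estimate for compound 3 in this assay is 25 nM, with a range from 8 nM to 80 nM.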

Compound 3, half-maximal inhibitory concentration: 51 nM
Beside the measured number, compound 3's estimate is 2.0-fold (0.31 log units) below it; the measured number falls inside the stated range.
By their numbers in this assay, from the lowest: compounds 2 and 1 (each within the scatter of the next); then compound 3.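

In this assay, placing 3-nitrophenyl on the saturated ring carbon gives a 2.8-fold higher number from compound 2 to compound 3 (0.45 log units; beyond the scatter) and a 2.2-fold higher number from compound 1 to compound 3 (0.35 log units; beyond the scatter). This position therefore does respond to the choice of aryl group, which the first two compounds, within the scatter of each other, could not show. No evidence here bears on why the number rises. Still open, on these data alone, is whether the change follows from the nitro group itself or from where it sits on the phenyl ring, which a 4-nitrophenyl group could help to separate. As far as these compounds go, how a 3-aminophenyl or 3-carboxyphenyl group would read at this same place also remains unknown.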